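A few compounds are considered here, and "the series" means these few. Any claim that something is new, unique, unknown or untested is made for them only; others in the source may bear on it.

Working notes on the series. In a functional assay on KB cells (Homo sapiens) for antiproliferative activity, read by sulforhodamine B assay, with a stated time of 3 days (on this read-out lower numbers stand for stronger inhibition of growth and higher numbers for weaker inhibition of growth), compound 1 `O=C(Nc1ccccn1)c1cccc(Nc2ncc(F)c(Nc3ccc(F)cc3)n2)c1` gives 20000 nM. Compound 2 `COc1ccc(NC(=O)c2cccc(Nc3ncc(F)c(Nc4ccc(F)cc4)n3)c2)cc1` reads > 10000 nM, which is a limit and not a number, so compound 2 stands on (the limit of > 10000 nM in this assay, at which 2 of the 3 values shown sit). Compound 3 `CN(C)c1ccc(C(=O)Nc2cccc(Nc3ncc(F)c(Nc4ccc(F)cc4)n3)c2)cc1` reads > 10000 nM, also a limit.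

The change to compound 4 `O=C(Nc1cccc(Nc2ncc(F)c(Nc3ccc(F)cc3)n2)c1)c1ccccc1` is benzamido in place of (4-methoxyphenyl)carbamoyl on an aromatic carbon, in words benzamido in place of (4-methoxyphenyl)carbamoyl on an aromatic carbon. Within the data shown here, the one measured step that bears on this change is a step that the limit leaves unreadable from compound 1 to compound 2, and it offers no size to carry over. No step beyond the scatter is therefore expected in this assay, and no direction can be argued from the data. Among the measured compounds shown here, compound 4 is expected to stay in the same weak range, given that compound 1 gives 20000 nM as the only actual number. For compound 4 the estimate is 15000 nM, with an expected range from 6000 nM to 40000 nM. The expected step is a step that the limit leaves unreadable from compound 2 to compound 4, and a reading that is only a limit would be no surprise.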

Compound 4, concentration for 50% growth inhibition: > 10000 nM
Compound 4 gave a limit, no number; the forecaster's own chance of this, stated with the estimate: 65%; the middle value does not contradict the limit.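

In this assay, among these compounds, compound 4 reads > 10000 nM, which is a limit, so no step from compound 1, compound 2 or compound 3 to compound 4 can be read. The compounds shown leave open how these amide groups on the shared core rank against one another: the limit of > 10000 nM in this assay, at which 3 of the 4 values shown sit.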